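Swapping bromo for ethyl on the aryl carbamate

The source may hold more compounds than are shown below. What is called first, only, known or untested is meant among the compounds shown, and "the series" means these compounds.

Measured compounds in a functional assay on RAW264.7 cells (Mus musculus) for inhibition, with a stated time of 30 min; on this read-out higher numbers stand for weaker inhibition and lower numbers for stronger inhibition:
compound 1 `C=C1C(=O)OC[C@@H]1CCOC(=O)Nc1ccc(I)cc1` gives 790 nM
compound 2 `C=C1C(=O)OC[C@@H]1CCOC(=O)Nc1ccc(C(C)C)cc1` gives 1580 nM
compound 3 `C=C1C(=O)OC[C@@H]1CCOC(=O)Nc1ccc(Br)cc1` gives 720 nM

Compound 3 holds the lowest number of the three, but its gap to compound 1 is within the scatter a 1.1-fold lower number from compound 1 to compound 3 (0.04 log units; within the scatter), and only compound 2 sits clearly apart, as a 2.2-fold lower number from compound 2 to compound 3 (0.34 log units; beyond the scatter) shows. Compound 4 `C=C1C(=O)OC[C@@H]1CCOC(=O)Nc1ccc(CC)cc1` is the next step from compound 3: ethyl in place of bromo on an aromatic carbon, the change sitting on an aromatic carbon para to a large group. Within the data shown here, two measured steps bear on it, both exchanging a halogen for an alkyl group or the reverse: a 2.0-fold higher number from compound 1 to compound 2 (0.30 log units; within the scatter) and a 2.2-fold lower number from compound 2 to compound 3 (0.34 log units; beyond the scatter). Both point the same way, alkyl giving the higher number, so a modest rise in this assay is expected for compound 4, about a 1.5-fold higher number from compound 3 to compound 4 (0.18 log units; within the scatter). Compound 4 is therefore estimated at 1100 nM, with a range from 550 nM to 2300 nM.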

Compound 4, half-maximal inhibitory concentration: 1260 nM
Compound 4: the middle estimate sits 1.1-fold (0.06 log units) below what was measured; the range from low to high includes it.
By their numbers in this assay, from the lowest: compounds 3, 1, 4 and 2 (each within the scatter of the next, the first and the last beyond it).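

In this assay ethyl on this aromatic carbon cannot be told apart from the other three groups: there is a 1.8-fold higher number from compound 3 to compound 4 (0.24 log units; within the scatter) against bromo, a 1.6-fold higher number from compound 1 to compound 4 (0.20 log units; within the scatter) against iodo, and a 1.3-fold lower number from compound 2 to compound 4 (0.10 log units; within the scatter) against isopropyl. The one clear gap so far, between compound 2 and compound 3, now has compound 4 within the scatter of both ends, so the split between alkyl groups and halogens is not sharp. No supporting evidence is available to explain these numbers.

As far as these compounds go, whether an amine, a carboxylic acid or a longer chain here would shift the number clearly stays open.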